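The source may report more compounds than this note shows. Statements on the series, on what has been measured and on what is new or still open speak of the compounds shown alone.

- Compound 1 `COc1ccc(-n2c(SCc3ccc(F)cc3)nnc2-c2cc(OC)c(OC)c(OC)c2)cc1`: 50700 nM
- Compound 2 `COc1ccc(C(=O)CSc2nnc(-c3cc(OC)c(OC)c(OC)c3)n2-c2ccc(OC)cc2)cc1`: > 60000 nM

Both compounds were tested in a functional assay on HT-29 cells (Homo sapiens) for inhibition, read by MTT assay, with a stated time of 48 h; on this read-out lower numbers stand for stronger inhibition and higher numbers for weaker inhibition. As far as these compounds go, compound 2 reads > 60000 nM, which is a limit of the assay and not a number, so its true position is unknown. This is the limit of > 60000 nM in this assay, at which 1 of the 2 values shown sits.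

Compound 3 `COc1ccc(-n2c(SCC(=O)C3CC3)nnc2-c2cc(OC)c(OC)c(OC)c2)cc1` keeps the core of compound 2 but carries cyclopropyl in place of 4-methoxyphenyl on a carbonyl carbon.

Within the data shown here, only one measured step bears on this change, and it does so loosely: an at least 1.1-fold higher number from compound 1 to compound 2 (0.07 log units; that floor lies within the scatter). That step swaps a different pair of groups, and it shows no change beyond the scatter. No clear gain or loss is therefore expected in this assay, and compound 3 is expected to remain weak, possibly at the limit. The expected size of the change is an at least 1.2-fold lower number from compound 2 to compound 3 (0.07 log units; that floor lies within the scatter). For compound 3 the estimate is 50000 nM, with an expected range of 20000 nM to 90000 nM.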

Compound 3, half-maximal inhibitory concentration: > 60000 nM
Compound 3 gave a limit, no number; the forecaster's own chance of this, stated with the estimate: 55%; at least 1.2-fold (0.07 log units) between middle value and limit.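

In this assay, putting cyclopropyl in place of 4-methoxyphenyl on the carbonyl carbon still gives a limit and not a number, so neither group at this position yields a readable value. Among these compounds, the step from compound 2 to compound 3 therefore cannot be read, and the only readable comparison for the new compound is an at least 1.1-fold higher number from compound 1 to compound 3 (0.07 log units; that floor lies within the scatter). Neither carbonyl-bearing chain shows a gain beyond the scatter over the 4-fluorophenyl group of compound 1, and the results now gather at one limit: the limit of > 60000 nM in this assay, at which 2 of the 3 values shown sit.

As far as these compounds go, how far compound 2 and compound 3 each lie past that limit remains unknown, so their order is open. Also open, from the compounds shown here alone, is whether an amine or a carboxylic acid in place of cyclopropyl on the carbonyl carbon would give a measurable value in this assay.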